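The source may hold more compounds than are shown below. What is called first, only, known or untested is meant among the compounds shown, and "the series" means these compounds.

Measured compounds:
compound 1, `COc1cc2c(Nc3ccc(C#N)cc3)ncnc2cc1OCCCN1CCCC1`: 14400 nM
compound 2, `COc1cc2c(Nc3ccc(C#N)cc3)ncnc2cc1OCCCN1CCC(C)CC1`: 16600 nM

Compound 1 carries the pyrrolidin-1-yl group on a saturated chain carbon, three bonds along the chain from an oxygen on an aromatic ring. Going by the values given here, in a functional assay on DU-145 cells (Homo sapiens) for antiproliferative activity, read by MTT assay, with a stated time of 72 h (on this read-out higher numbers stand for weaker inhibition and lower numbers for stronger inhibition), compound 1 gives 14400 nM, the lowest of the two numbers so far; its nearest neighbour is compound 2, which in this assay gives 16600 nM. Among the compounds with values here, the only step available, a 1.2-fold higher number from compound 1 to compound 2 (0.06 log units; within the scatter), comes from putting 4-methylpiperidin-1-yl in place of pyrrolidin-1-yl at that position, and it lies within the scatter.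

Compound 3, `CCOC(=O)C1CCN(CCCOc2cc3ncnc(Nc4ccc(C#N)cc4)c3cc2OC)CC1`, has not yet been tested. Compared with compound 1 the change is 4-(ethoxycarbonyl)piperidin-1-yl in place of pyrrolidin-1-yl on a saturated chain carbon, three bonds along the chain from an oxygen on an aromatic ring.

Within the data shown here, the step from compound 1 to compound 2 is the one measured change that bears on this: the same pyrrolidin-1-yl is replaced by a six-membered ring at the same place, and it produced no shift beyond the scatter. The entering group here adds an ethoxycarbonyl substituent, for which no measured step exists, so the data give no reason to expect a shift in either direction. Compound 3 is therefore expected to show a step of about a 1.0-fold higher number from compound 1 to compound 3 (0.02 log units; within the scatter), within the scatter. The estimate for compound 3 in this assay is 15000 nM, with a range from 7000 nM to 32000 nM.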

Compound 3, half-maximal inhibitory concentration: 52300 nM
For compound 3 the middle estimate is 3.5-fold (0.54 log units) below the measured one; measured number outside the range, above it.
By their numbers in this assay, from the lowest: compounds 1 and 2 (each within the scatter of the next); then compound 3.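

In this assay this position turns out not to be indifferent to the group placed on the chain: 4-(ethoxycarbonyl)piperidin-1-yl in place of pyrrolidin-1-yl gives a 3.6-fold higher number from compound 1 to compound 3 (0.56 log units; beyond the scatter), whereas 4-methylpiperidin-1-yl had stayed within the scatter. Ethoxycarbonyl in place of methyl on a saturated ring carbon gives a 3.2-fold higher number from compound 2 to compound 3 (0.50 log units; beyond the scatter), so among these three compounds the six-membered ring alone does not go with a shift, and the shift appears only once ethoxycarbonyl is present. Nothing at hand says why the number rises with this change.

The compounds shown leave open whether the shift belongs to the ethoxycarbonyl group as a whole or would also appear with a carboxylic acid or a primary amide on the same ring carbon. They also leave open whether another ring on the chain, such as morpholin-4-yl or piperazin-1-yl, or a longer chain between the oxygen and the ring, would move the number in either direction from that of compound 1.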